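This account rests on a few compounds, and the source may have more. Where it says the series, first, only, none or still open, it means among the compounds named here.

In a functional assay on HCT-116 cells (Homo sapiens) for cytotoxicity, read by resazurin assay, with a stated time of 48 h (a lower number here means that less compound is needed, a higher number that more compound is needed for the effect), compound 3 `O=C(/C=C/c1ccccc1)c1ccc(NC(=O)c2cccs2)cc1` gives 16000 nM, the lowest of the three numbers recorded. Compound 2 `Nc1ccc(C(=O)/C=C/c2ccccc2)cc1` gives 23000 nM, and the step of a 1.4-fold lower number from compound 2 to compound 3 (0.16 log units; within the scatter) is within the scatter, so the two cannot be ordered. Compound 1 `O=C(/C=C/c1ccco1)c1ccc(NC(=O)c2ccccc2)cc1` gives 59000 nM, which is beyond the scatter from compound 3.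

Compound 4 `O=C(/C=C/c1ccccc1)c1ccc(NC(=O)c2ccccc2)cc1` is compound 3 with one change: phenyl in place of thiophen-2-yl on a carbonyl carbon. Within the data shown here, no measured pair shows this exchange, so there is no direct step to lean on. Among the measured compounds shown here, compound 1 carries the benzoyl group of compound 4 but differs at the other end of the enone, so its value says only that a benzoyl compound can give a high number. The amide introduction from compound 2 to compound 3 moved the number little, which suggests the group on the carbonyl carbon has modest weight. On this footing compound 4 is expected to give 25000 nM, with a range from 9000 nM to 70000 nM. This estimate means a step of a 1.6-fold higher number from compound 3 to compound 4 (0.19 log units; within the scatter), which is not expected to clear the scatter.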

Compound 4, half-maximal effective concentration: 28000 nM
For compound 4 the middle estimate is 1.1-fold (0.05 log units) below the measured one, within the range that was stated.
By their numbers in this assay, from the lowest: compounds 3, 2 and 4 (each within the scatter of the next); then compound 1.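

In this assay the direct pair gives a 1.8-fold higher number from compound 3 to compound 4 (0.24 log units; within the scatter) for phenyl in place of thiophen-2-yl on a carbonyl carbon, so the two rings cannot be told apart at this position. Benzoyl in place of hydrogen on the nitrogen gives a 1.2-fold higher number from compound 2 to compound 4 (0.09 log units; within the scatter) and likewise cannot be told apart from the unsubstituted amine, whereas the only change here to clear the scatter lies elsewhere, with a 2.1-fold lower number from compound 1 to compound 4 (0.32 log units; beyond the scatter) for phenyl in place of furan-2-yl on a double-bonded chain carbon, and that step is modest. Nothing at hand gives a reason for any of these steps.

Going by these compounds, whether a carboxylic acid or an aliphatic amine on that carbonyl carbon would move the number beyond the scatter remains open. Also open, on these data alone, is whether furan-2-yl on the chain carbon would have the same effect alongside a (thiophen-2-yl)carbonyl group.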